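The source may report more compounds than this note shows. Statements on the series, on what has been measured and on what is new or still open speak of the compounds shown alone.

In a functional assay on HepG2 cells (Homo sapiens) for inhibition, read by MTT assay (a higher number here means a weaker inhibitor, a lower number a stronger inhibitor), compound 1 `COc1cc2ncnc(Nc3ccc(NC(=O)c4cccc(F)c4)cc3)c2cc1OC` gives 8200 nM and compound 2 `COc1cc2ncnc(Nc3ccc(NC(=O)c4ccc(Cl)cc4)cc3)c2cc1OC` gives 28000 nM, the higher of the two numbers. Compound 3 `COc1cc2ncnc(Nc3ccc(NC(=O)c4ccc(C(F)(F)F)cc4)cc3)c2cc1OC` differs from compound 2 by trifluoromethyl in place of chloro on an aromatic carbon, para to a large group. For the measured compounds named here, no measured step covers this exchange. The nearest is a 3.4-fold higher number from compound 1 to compound 2 (0.53 log units; beyond the scatter), a modest change of the group on the carbonyl carbon, so only a small shift is expected, in no clear direction. The expected step is a 1.1-fold lower number from compound 2 to compound 3 (0.05 log units; within the scatter), which would not be a clear change. For compound 3 the estimated value is 25000 nM, with an expected range of 10000 nM to 60000 nM.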

Compound 3, half-maximal inhibitory concentration: > 100000 nM
Compound 3: no number, only a limit (the forecaster's own chance of this, stated with the estimate: 15%); middle value at least 4.0-fold (0.60 log units) from the limit.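

In this assay compound 3 gives > 100000 nM, which is a limit of the assay and not a number. Trifluoromethyl in place of chloro, para to a large group, is not a silent exchange, with an at least 3.5-fold higher number from compound 2 to compound 3 (0.55 log units; beyond the scatter). The group on the carbonyl carbon can move the number much further than the earlier pair showed, with an at least 12-fold higher number from compound 1 to compound 3 (1.08 log units; beyond the scatter). On these data alone, the full size of both steps stays unknown. As far as these compounds go, whether an amine or a carboxylic acid at this place would give a lower number than compound 1 also remains open.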